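This account rests on a few compounds, and the source may have more. Where it says the series, first, only, none or still open, it means among the compounds named here.

Measured in a functional assay on CHO cells for agonist activity at Alpha-1A adrenergic receptor (Homo sapiens), read by FLIPR and calcium flux; on this read-out lower numbers stand for smaller maximal responses and higher numbers for larger maximal responses:
- compound 1, `COc1c(C)ccc2c1CCC2c1ncc[nH]1`: 40%
- compound 2, `c1cc(-c2ccn[nH]2)c2c(c1)C(c1ncc[nH]1)CC2`: 83%
- compound 3, `CCS(=O)(=O)Nc1cccc(Cc2c[nH]cn2)c1`: 96%

Compound 2 holds the second highest of the three values in this assay. Its nearest neighbour is compound 3, whose value sits higher by a gap beyond the usual scatter; its furthest is compound 1, whose value sits lower by a much wider gap, also beyond the scatter.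

Compound 4, `c1cc(-c2cn[nH]c2)c2c(c1)C(c1ncc[nH]1)CC2`, is not yet measured. It differs from compound 2 by 1H-pyrazol-4-yl in place of 1H-pyrazol-5-yl on an aromatic carbon; the two have the same atoms, joined differently. Going by the values given here, no pair of measured compounds shows a step of one change, so there is no precedent for this kind of move in this assay. With a group of identical composition re-attached, the expected step in this assay is small, in no clear direction, likely within the scatter. Compound 4 is estimated at 80%, range 55% to 100%, meaning an expected step of a number 3 percentage points lower from compound 2 to compound 4 (within the scatter).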

Compound 4, largest response reached (Emax), in percent of the reference or control that the assay uses: 84%
Beside the measured number, compound 4's estimate is 4 percentage points below it; measured number inside the range.
By their numbers in this assay, from the lowest: compound 1; then compounds 2 and 4 (each within the scatter of the next); then compound 3.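

In this assay the re-attached group gives a number 1 percentage points higher from compound 2 to compound 4 (within the scatter), so on this aromatic carbon, ortho to a fused ring and meta to a fused ring, the read-out does not separate 1H-pyrazol-4-yl from 1H-pyrazol-5-yl. This is the only one-place step shown in the series, and the maximal response holds through this change of attachment. No measured evidence bears on this result.

From the compounds shown here alone, whether an amine or a carboxylic acid on this same carbon would keep the response at this level stays open.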